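The compounds below may be only part of what the source reports. "The series", "measured", "known", "first", "only" and "open" are said of these compounds alone.

Measured so far in a functional assay on A-375 cells (Homo sapiens) for cytotoxicity, read by CCK-8 assay, with a stated time of 24 h (a lower number here means a stronger inhibitor, a higher number a weaker inhibitor), on this series
Compound 1 `COc1ccccc1Oc1c(N)nc(-c2ccc(Cl)cc2)nc1Cl` gives 1030 nM here
Compound 2 `COc1ccccc1Oc1c(N)nc(-c2ccc(F)cc2)nc1OCCO` gives 15900 nM here

Compound 2 holds the higher of the two numbers, and its gap to compound 1 lies beyond the scatter. Compound 3 `COc1ccccc1Oc1c(N)nc(-c2ccc(Cl)cc2)nc1OCCO` is the next entry. It has chloro in place of fluoro on an aromatic carbon, para to a large group, read as 4-fluorophenyl to 4-chlorophenyl chloro in place of fluoro on an aromatic carbon relative to compound 2. Within the data shown here, no measured pair isolates this swap. A small move toward a lower number in this assay is expected, close to the scatter. The 4-chlorophenyl is shared with compound 1 at 1030 nM but that compound also differs elsewhere, so it offers only weak guidance. The expected change is a 1.8-fold lower number from compound 2 to compound 3 (0.25 log units; within the scatter) on this estimate. For compound 3 the estimated value is 9000 nM with an expected range from 3000 nM to 22000 nM in this assay once measured.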

Compound 3, half-maximal inhibitory concentration: > 80000 nM
Compound 3: no number, only a limit; the forecaster's own chance of this, stated with the estimate: 10%; middle value at least 8.8-fold (0.94 log units) away from the limit.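

Compound 3 is reported only as a limit of this assay, not as a number: the limit of > 80000 nM in this assay, at which 1 of the 3 values shown sits. The swap from 4-fluorophenyl to 4-chlorophenyl, with the 2-hydroxyethoxy group kept, gives an at least 5.0-fold higher number from compound 2 to compound 3 (0.70 log units; beyond the scatter), the first sign that this aromatic carbon, para to a large group, is sensitive to the choice of halogen. On these data alone, with the 4-chlorophenyl kept, 2-hydroxyethoxy in place of chloro gives an at least 77-fold higher number from compound 1 to compound 3 (1.89 log units; beyond the scatter), so the other substituent also matters in this assay, and both steps are lower bounds whose true size remains unknown.

As far as these compounds go, whether fluoro would also give a higher number than chloro with chloro rather than 2-hydroxyethoxy at the other site remains open. Also open, from the compounds shown here alone, is how a methyl or bromo on the phenyl, or an amine or longer alkoxy chain in place of 2-hydroxyethoxy, would read here.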